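Swapping a chloro for an amino on the phenoxy ring

The source may hold more compounds than are shown below. What is called first, only, known or untested is meant among the compounds shown, and "the series" means these compounds.

Measured compounds:
- compound 1 `CC(Nc1ccccc1Oc1cccc(F)c1)=C1C(=O)CC(c2ccccc2)CC1=O`: 170 nM
- compound 2 `CC(Nc1ccccc1Oc1ccc(Cl)cc1)=C1C(=O)CC(c2ccccc2)CC1=O`: 190 nM
- compound 3 `COc1ccc(Oc2ccccc2NC(C)=C2C(=O)CC(c3ccccc3)CC2=O)cc1OC`: 160 nM

All three were tested in a functional assay on CCRF-CEM cells (Homo sapiens) for antiproliferative activity, read by cell counting, with a stated time of 96 h; a lower number here means a stronger inhibitor, a higher number a weaker inhibitor. Compound 2 gives the highest of the three numbers, but its gaps to the others are small: a 1.1-fold higher number from compound 1 to compound 2 (0.05 log units; within the scatter) and a 1.2-fold lower number from compound 2 to compound 3 (0.07 log units; within the scatter) both stay within the scatter, as does a 1.1-fold lower number from compound 1 to compound 3 (0.03 log units; within the scatter). So the three phenoxy substituents tried so far behave alike.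

Compound 4 `CC(Nc1ccccc1Oc1ccc(N)cc1)=C1C(=O)CC(c2ccccc2)CC1=O` is not yet measured. It differs from compound 2 in one spot: amino in place of chloro on an aromatic carbon. For the measured compounds named here, the new group brings a hydrogen-bond donor and acceptor, which none of the measured steps tested; those steps only exchanged halogens and methoxy groups and all landed within the scatter. Going by the values given here, with no measured step pointing either way, compound 4 is expected to sit close to compound 2, so the expected step is a 1.1-fold higher number from compound 2 to compound 4 (0.02 log units; within the scatter), not beyond the scatter. The estimate for compound 4 is 200 nM, with a range from 100 nM to 450 nM.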

Compound 4, half-maximal inhibitory concentration: 37 nM
Estimate against measurement, compound 4: 5.4-fold (0.73 log units) above; the measured number lies below the stated range.
By their numbers in this assay, from the lowest: compound 4; then compounds 3, 1 and 2 (each within the scatter of the next).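

For the compounds shown here, at this spot on the phenoxy ring, amino in place of chloro produces the first step beyond the scatter in this assay (a 5.1-fold lower number from compound 2 to compound 4 (0.71 log units; beyond the scatter)). Compound 4 also separates from the other two compounds, with a 4.3-fold lower number from compound 3 to compound 4 (0.64 log units; beyond the scatter) and a 4.6-fold lower number from compound 1 to compound 4 (0.66 log units; beyond the scatter), and so has the lowest number of the four. The phenoxy ring is therefore not indifferent to its substituent, as the three earlier compounds suggested, and the amino group, which brings a hydrogen-bond donor and acceptor, stands apart from the chloro, fluoro and methoxy groups; no available evidence explains this difference.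

The compounds shown do not reveal whether the hydrogen-bond donor and acceptor count matters or something particular to the amino group does. A hydroxyl, methylamino or acetamido group on the same aromatic carbon would help separate these possibilities.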